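This account rests on a few compounds, and the source may have more. Where it says the series, first, only, none or still open, it means among the compounds named here.

Of the compounds shown here, three of a shared core have been tested in a functional assay on MCF7 cells (Homo sapiens) for antiproliferative activity, read by MTT assay, with a stated time of 72 h; a higher number here means a weaker inhibitor, a lower number a stronger inhibitor. Compound 1 `COc1cc2ncnc(N3CCc4ccccc43)c2cc1NC(=O)/C=C/CN1CCCC1` gives 1510 nM there. Compound 2 `COc1cc2ncnc(N3CCc4ccccc43)c2cc1NC(=O)/C=C/CN1CCCCC1` differs from compound 1 in one place, (piperidin-1-yl in place of pyrrolidin-1-yl on a saturated chain carbon bound to a double-bonded chain carbon), and compound 2 gives 1680 nM in this assay; the step of a 1.1-fold higher number from compound 1 to compound 2 (0.05 log units; within the scatter) is the measured size of that change. Compound 3 `COc1cc2ncnc(N3CCCc4ccccc43)c2cc1NC(=O)/C=C/CN1CCCC1` carries a different core, and how the two cores differ is counted as 1,2,3,4-tetrahydroquinolin-1-yl in place of 2,3-dihydro-1H-indol-1-yl on an aromatic carbon. In this assay compound 3 gives 3190 nM, and the step of a 2.1-fold higher number from compound 1 to compound 3 (0.32 log units; beyond the scatter) sets compound 3 as the highest of the three numbers.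

Compound 4 `COc1cc2ncnc(N3CCCc4ccccc43)c2cc1NC(=O)/C=C/CN1CCCCC1` has not yet been measured. It stands to compound 3 as compound 2 stands to compound 1: the change is piperidin-1-yl in place of pyrrolidin-1-yl on a saturated chain carbon bound to a double-bonded chain carbon, and it sits at the same place, on a saturated chain carbon bound to a double-bonded chain carbon, so it is the same change made on the core of compound 3 instead of the core of compound 1. The change has been seen only once among these compounds, so no pattern across cores can be claimed. Going by the values given here, the expectation for the step from compound 3 to compound 4 is a 1.1-fold higher number from compound 3 to compound 4 (0.04 log units; within the scatter), resting on the one measured example, the step of a 1.1-fold higher number from compound 1 to compound 2 (0.05 log units; within the scatter), which lay within the scatter. Compound 4 is therefore estimated to give 3500 nM in this assay, with a range from 1800 nM to 7000 nM expected.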

Compound 4, half-maximal inhibitory concentration: 3930 nM
Beside the measured number, compound 4's estimate is 1.1-fold (0.05 log units) below it; the range from low to high includes it.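

In this assay, putting piperidin-1-yl in place of pyrrolidin-1-yl on the core of compound 3 gives a 1.2-fold higher number from compound 3 to compound 4 (0.09 log units; within the scatter), and this step agrees with the one seen for the same change on the core of compound 1: the same change on two cores in this assay, a 1.1-fold higher number (0.05 log units; within the scatter) from compound 1 to compound 2 and a 1.2-fold higher number (0.09 log units; within the scatter) from compound 3 to compound 4, 1.1-fold (0.04 log units) apart, within the scatter of two such steps. The exchange of the other group, 1,2,3,4-tetrahydroquinolin-1-yl in place of 2,3-dihydro-1H-indol-1-yl on an aromatic carbon, gives a 2.3-fold higher number from compound 2 to compound 4 (0.37 log units; beyond the scatter) when piperidin-1-yl is present, and it too agrees with its earlier step: the same change on two cores in this assay, a 2.1-fold higher number (0.32 log units; beyond the scatter) from compound 1 to compound 3 and a 2.3-fold higher number (0.37 log units; beyond the scatter) from compound 2 to compound 4, 1.1-fold (0.04 log units) apart, within the scatter of two such steps. Across these four compounds the two changes therefore carry over from one core to the other without a measurable interaction, but this rests on a single pair of cores and a single pair of rings in one cell assay, and since the ring exchange on the chain stays within the scatter on both cores, its agreement shows only that it made no clear difference in either case.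

Still open, going by these compounds, is whether an acyclic amine such as dimethylamino, or morpholin-4-yl, on the saturated chain carbon bound to a double-bonded chain carbon would carry over as evenly. On these data alone, it is equally open whether the same holds with an anilino group on the aromatic carbon, or with a longer chain ahead of the amine.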